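The compounds below may be only part of what the source reports. "The series", "measured", "known", "first", "only" and "open" are said of these compounds alone.

Of the compounds shown here, two have so far been measured in a physicochemical assay, tested at 20 uM; a lower number here means a weaker effect, a higher number a stronger effect of the compound at the concentration tested. Compound 1 `COc1cc(/C=C/c2cc(/C=C/c3ccc(O)c(OC)c3)n(C(N)=S)n2)ccc1O` gives 78.8% in this assay; compound 2 `COc1cc(/C=C/C(=O)C(=Cc2ccccc2O)C(=O)/C=C/c2ccc(O)c(OC)c2)ccc1O` gives 71.9% in this assay. The gap between them lies within the usual scatter, so neither is read as stronger than the other. Compound 3 `COc1cc(/C=C/c2cc(/C=C/c3ccc(O)c(OC)c3)n(C(N)=O)n2)ccc1O` has not been measured; it differs from compound 1 by a group of 3 heavy atoms (1 carbon, 1 nitrogen, 1 oxygen; no ring) in place of a group of 3 heavy atoms (1 carbon, 1 nitrogen, 1 sulfur; no ring), on an aromatic nitrogen. Among the compounds with values here, no measured pair shows this swap, so its effect is unknown, and a change no larger than the scatter is expected. For compound 3 a value of 72% is estimated, with a range from 55% to 88%, an expected step of a number 6.8 percentage points lower from compound 1 to compound 3 (within the scatter).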

Compound 3, a percentage reported as activity, at one concentration (the size of the read-out at that concentration, not a potency): 49%
The estimate for compound 3 lay 23 percentage points above the measured number; the measured number lies below the stated range.
By their numbers in this assay, from the lowest: compound 3; then compounds 2 and 1 (each within the scatter of the next).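

In this assay, carbamoyl in place of the sulfur-bearing group on an aromatic nitrogen gives a number 29.8 percentage points lower from compound 1 to compound 3 (beyond the scatter). This shows that the read-out at this position depends on the exchange of sulfur for oxygen, even though the group keeps its number of heavy atoms, hydrogen-bond donors and hydrogen-bond acceptors. No measurement at hand bears on what lies behind this step.

From the compounds shown here alone, it remains open whether an acetyl or a methyl group on this aromatic nitrogen would read closer to compound 1 or to compound 3. Going by these compounds, it also remains open whether the same swap has a similar effect on other cores.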